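A Saturated Ring Swap on the Lactam Nitrogen

A few compounds are considered here, and "the series" means these few. Any claim that something is new, unique, unknown or untested is made for them only; others in the source may bear on it.

Compound 1 `CC(C)(O)c1ccc(-c2cnc3c(n2)N(CC2CCOCC2)C(=O)CN3)cn1` was examined in an ADME assay on the whole organism for pharmacokinetics, with Rattus norvegicus as the target, at a dose of 5 mg/kg by the oral route (a higher number here means more compound in the circulation at the dose given, a lower number less compound in the circulation), where compound 1 gives 3800 ng.h/mL. Compound 2 `CO[C@H]1CC[C@H](CN2CC(=O)Nc3ncc(-c4ccc(C(C)(C)O)nc4)nc32)CC1` carries a different substituent on the shared core; in this assay compound 2 gives 2980 ng.h/mL. These two numbers lie within the scatter of each other, so no order between compound 1 and compound 2 can be read from them.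

Compound 3 `CO[C@H]1CC[C@H](N2C(=O)CNc3ncc(-c4ccc(C(C)(C)O)nc4)nc32)CC1` differs from compound 1 in one place: 4-methoxycyclohexyl in place of (oxan-4-yl)methyl on an amide-type nitrogen in a ring. Among the measured compounds shown here, since no measured pair shows this change directly, the account can only draw on what compound 1 and compound 2 show.

On that basis compound 3 is expected to give 3000 ng.h/mL in this assay, with a range from 1200 ng.h/mL to 7500 ng.h/mL. The step of a 1.3-fold lower number from compound 1 to compound 3 (0.10 log units; within the scatter) is estimated to stay within the scatter, because compound 1 gives 3800 ng.h/mL and compound 2 gives 2980 ng.h/mL with neither standing apart from the other.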

Compound 3, area under the concentration-time curve: 10300 ng.h/mL
The estimate for compound 3 lay 3.4-fold (0.54 log units) below the measured number, and the stated range ends below it.
By their numbers in this assay, from the lowest: compounds 2 and 1 (each within the scatter of the next); then compound 3.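

The substituent on this amide-type nitrogen does matter in this assay: compound 1 and compound 2 stood within the scatter of each other, whereas 4-methoxycyclohexyl in place of (oxan-4-yl)methyl gives a 2.7-fold higher number from compound 1 to compound 3 (0.43 log units; beyond the scatter) and sets compound 3 apart as the highest of the three. This modest step comes with no change in the counts of hydrogen-bond donors and acceptors and no net charge on either group. Nothing shown bears on why the number rises.

Among the compounds shown here, the single step changes the ring atoms, the group's size and the defined stereocentres together, so their shares remain unseparated. As far as these compounds go, how an amine or a longer chain on this nitrogen would fare in this assay also stays open.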